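The compounds below may be only part of what the source reports. "The series", "measured", "known", "first", "only" and "open" are said of these compounds alone.

In a functional assay on HT-29 cells (Homo sapiens) for antiproliferative activity, read by MTT assay, with a stated time of 72 h (a higher number here means a weaker inhibitor, a lower number a stronger inhibitor), compound 1 `Nc1nc(N)c2cc(CSC(=S)N3CCN(c4ccccc4)CC3)ccc2n1` gives 2760 nM and compound 2 `COc1ccc(N2CCN(C(=S)SCc3ccc4nc(N)nc(N)c4c3)CC2)cc1` gives 1770 nM while compound 3 `Cc1ccc(N2CCN(C(=S)SCc3ccc4nc(N)nc(N)c4c3)CC2)cc1` gives 3020 nM as its reading. Compound 3 stands level with the other two. The gaps are a 1.1-fold higher number from compound 1 to compound 3 (0.04 log units; within the scatter) and a 1.7-fold higher number from compound 2 to compound 3 (0.23 log units; within the scatter) in size. Compound 4 `Cc1ccc(N2CCN(C(=S)SCc3ccc4nc(N)nc(N)c4c3)CC2)c(C)c1` adds one group to compound 3 as methyl in place of hydrogen on an aromatic carbon in the change from 4-methylphenyl to 2,4-dimethylphenyl, ortho to a large group. Among the measured compounds shown here, the nearest precedent, a 1.1-fold higher number from compound 1 to compound 3 (0.04 log units; within the scatter) for methyl in place of hydrogen, and a 1.6-fold lower number from compound 1 to compound 2 (0.19 log units; within the scatter) for methoxy in place of hydrogen are both small, though neither group sits ortho to a large group. In this assay no step beyond the scatter is expected, and the estimated move is a 1.1-fold lower number from compound 3 to compound 4 (0.03 log units; within the scatter) only. Compound 4 is estimated at 2800 nM with an expected range from 1300 nM to 6000 nM in this series.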

Compound 4, half-maximal inhibitory concentration: 2970 nM
Compound 4: middle estimate off by 1.1-fold (0.03 log units), on the low side; low and high end bracket the measured number.
By their numbers in this assay, from the lowest: compounds 2, 1, 4 and 3 (each within the scatter of the next).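

In this assay, methyl in place of hydrogen on an aromatic carbon, ortho to a large group, gives a 1.0-fold lower number from compound 3 to compound 4 (0.01 log units; within the scatter), so this place takes a methyl group with no step beyond the scatter. The 2,4-dimethylphenyl group also stays within the scatter of the phenyl and 4-methoxyphenyl groups, at a 1.1-fold higher number from compound 1 to compound 4 (0.03 log units; within the scatter) and a 1.7-fold higher number from compound 2 to compound 4 (0.22 log units; within the scatter). Nothing measured here accounts for this result.

From the compounds shown here alone, what a methoxy group, a chlorine atom or a carboxylic acid would give at this same place remains open. All four numbers lie within the scatter, so the compounds shown define no trend across the aryl substituents.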